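The compounds below may be only part of what the source reports. "The series", "measured", "known", "first", "only" and "open" are said of these compounds alone.

Compound 1, `Cn1ccc2c(Oc3ccc(F)cc3F)ncnc21`: in an assay on HEK293-TREx cells for antagonist activity at transient receptor potential cation channel subfamily A member 1 (Homo sapiens), read by fluorescence and calcium flux, with a stated time of 72 h (a lower number here means a stronger inhibitor, a higher number a weaker inhibitor), compound 1 gives > 32000 nM, which is a limit of the assay.
Compound 2, `COc1cc2ccnc(Oc3ccc(F)cc3F)c2cc1OC`: in this assay compound 2 gives 630 nM.
Compound 3, `COc1ccc2c(Oc3ccc(F)cc3F)nccc2c1`: in this assay compound 3 gives 1300 nM.

Compound 3 holds the higher of the two numbers obtained so far. For the measured compounds named here, the only other number belongs to compound 2, and the two are separated by a 2.1-fold higher number from compound 2 to compound 3 (0.31 log units; beyond the scatter), a change in which hydrogen replaces methoxy on an aromatic carbon. Compound 1 reaches only (the limit of > 32000 nM in this assay, at which 1 of the 3 values shown sits), so it gives no number and offers nothing for sizing steps.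

Compound 4, `Fc1ccc(Oc2nccc3ccccc23)c(F)c1`, has not yet been measured. It differs from compound 3 as follows: hydrogen in place of methoxy on an aromatic carbon. Going by the values given here, this is the same kind of change that was already seen once, the removal of a methoxy from the shared core; the single measured step bearing on it is the one from compound 2 to compound 3, which rose modestly. Among the compounds with values here, one step is a thin basis, but it points upward, and no other measured pair argues against it. A step of roughly that size, in the same direction, is therefore expected in this assay: compound 4 is estimated at 2600 nM, in the range 1000 nM to 7000 nM, which is expected to correspond to a 2.0-fold higher number from compound 3 to compound 4 (0.30 log units; within the scatter).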

Compound 4, half-maximal inhibitory concentration: 3100 nM
For compound 4 the middle estimate is 1.2-fold (0.08 log units) below the measured one; the measured number falls inside the stated range.
By their numbers in this assay, from the lowest: compound 2; then compound 3; then compound 4. At a limit, above all of these: compound 1.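

In this assay, taking off the remaining methoxy gives a 2.4-fold higher number from compound 3 to compound 4 (0.38 log units; beyond the scatter) and so provides a second reading of this change, now at the carbon that is meta to a fused ring and para to a fused ring. Set beside a 2.1-fold higher number from compound 2 to compound 3 (0.31 log units; beyond the scatter) it makes two steps in the same direction, each printed as beyond the scatter, and no compound in the methoxy set of compounds 2, 3 and 4 goes against that trend. Compound 4, which carries no methoxy at all, gives 3100 nM in this assay as a true number rather than a limit, so the methoxy groups are not required for a reading here, though each one present goes with a lower number in this short set.

As far as these compounds go, what remains open is whether the trend belongs to methoxy itself or to any group at this carbon, since a hydroxyl, an ethoxy, a chlorine or an amine there would separate those readings. Nothing measured in the series gives a cause for either step.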